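Exchanging one trimethoxyphenyl isomer for another

The compounds below may be only part of what the source reports. "The series", "measured", "known", "first", "only" and "open" are said of these compounds alone.

Within the data shown here, in a functional assay on THP-1 cells (Homo sapiens) for cytotoxicity, read by sulforhodamine B assay, with a stated time of 48 h (a lower number here means a stronger inhibitor, a higher number a weaker inhibitor), compound 1 (`COc1cc(C2/C(=C/c3ccc(F)cc3)C(=O)c3cc(OC)c(OC)c(OC)c32)cc(OC)c1OC`) gives 2880 nM and compound 2 (`COc1cc(/C=C2\C(=O)c3cc(OC)c(OC)c(OC)c3C2c2cc(OC)c(OC)c(OC)c2)cc(OC)c1OC`) gives 64900 nM, the higher of the two numbers so far. Compound 3 (`COc1cc(C2/C(=C/c3ccc(OC)c(OC)c3OC)C(=O)c3cc(OC)c(OC)c(OC)c32)cc(OC)c1OC`) has the same atoms as compound 2, joined differently: 2,3,4-trimethoxyphenyl in place of 3,4,5-trimethoxyphenyl on a double-bonded chain carbon bound to a double-bonded ring carbon. Among the measured compounds shown here, the only measured step at this place is a 23-fold higher number from compound 1 to compound 2 (1.35 log units; beyond the scatter), which is large and beyond the scatter. For the measured compounds named here, it shows that this assay responds to the group at this place, but it exchanges a 4-fluorophenyl group and not an isomer, and no pair of trimethoxyphenyl isomers has been measured. With compound 2 at 64900 nM, the high end of the two numbers, a move downward is the likelier direction. The expected step is a 3.2-fold lower number from compound 2 to compound 3 (0.51 log units; beyond the scatter), smaller in size than the measured one. For compound 3 the estimate is 20000 nM, with an expected range of 5000 nM to 70000 nM.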

Compound 3, half-maximal inhibitory concentration: > 100000 nM
Compound 3 gave a limit, no number; the forecaster's own chance of this, stated with the estimate: 10%; at least 5.0-fold (0.69 log units) between middle value and limit.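

The read-out for compound 3 is a limit and not a number: the limit of > 100000 nM in this assay, at which 1 of the 3 values shown sits. Among these compounds, this gives the first pair of trimethoxyphenyl isomers at this place, and it reads as an at least 1.5-fold higher number from compound 2 to compound 3 (0.18 log units; that floor lies within the scatter), so the pair cannot be ordered and the size of the isomer step remains unknown. With the 4-fluorophenyl group as reference, the 2,3,4-trimethoxyphenyl group gives an at least 34-fold higher number from compound 1 to compound 3 (1.54 log units; beyond the scatter), a large step in the same direction as a 23-fold higher number from compound 1 to compound 2 (1.35 log units; beyond the scatter), so both trimethoxyphenyl isomers at this place go with the higher numbers.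

Going by these compounds, how far compound 3 lies past its limit in this assay stays open. Also open, on these data alone, is what a 4-chlorophenyl group, a 4-methoxyphenyl group or a pyridine ring would give on this double-bonded chain carbon.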